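The compounds below may be only part of what the source reports. "The series", "measured", "known", "first", "only" and "open" are said of these compounds alone.

The three measured compounds share one core. Compound 1 `CC(=O)Nc1c(C(O)(C(F)(F)F)C(F)(F)F)ccc2ccccc12` gives 18 nM in an assay on LtK cells with ATP-sensitive inward rectifier potassium channel 11 (Homo sapiens) as the target; on this read-out higher numbers stand for an effect only at larger amounts of compound and lower numbers for an effect already at smaller amounts. Compound 2 `COCC(=O)Nc1c(C(O)(C(F)(F)F)C(F)(F)F)ccc2ccccc12` gives 213 nM in this assay, and compound 3 `O=C(NCCCCCCCl)Nc1c(C(O)(C(F)(F)F)C(F)(F)F)ccc2ccccc12` gives 4840 nM in this assay, the highest number of the three. Compound 4 `O=C(Nc1c(C(O)(C(F)(F)F)C(F)(F)F)ccc2ccccc12)c1cccc([N+](=O)[O-])c1` carries 3-nitrophenyl in place of (6-chlorohexyl)amino on a carbonyl carbon. Among the measured compounds shown here, the steps that bear on this carbonyl carbon are a 270-fold higher number from compound 1 to compound 3 (2.43 log units; beyond the scatter) and a 23-fold higher number from compound 2 to compound 3 (1.36 log units; beyond the scatter): bringing in (6-chlorohexyl)amino raised the number strongly both times. Taking that group away again should lower the number, yet no measured compound carries an aromatic ring on that carbonyl carbon, so the size is uncertain. Compound 4 is therefore expected to give 300 nM in this assay, within 40 nM to 2500 nM. The expected step is a 16-fold lower number from compound 3 to compound 4 (1.21 log units; beyond the scatter).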

Compound 4, half-maximal effective concentration: 117 nM
Compound 4: the middle estimate sits 2.6-fold (0.41 log units) above what was measured, within the range that was stated.
By their numbers in this assay, from the lowest: compound 1; then compounds 4 and 2 (each within the scatter of the next); then compound 3.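

With an aromatic ring on this carbonyl carbon, this assay shows a 41-fold lower number from compound 3 to compound 4 (1.62 log units; beyond the scatter), so the high number of compound 3 is not shared by every large group at this position. The 3-nitrophenyl and methoxymethyl groups cannot be told apart, with a 1.8-fold lower number from compound 2 to compound 4 (0.26 log units; within the scatter), while the small methyl group still holds the lowest number, with a 6.5-fold higher number from compound 1 to compound 4 (0.81 log units; beyond the scatter). No supporting data explain these differences.

On these data alone, whether a plain phenyl or a pyridine ring would come closer to compound 1 remains open. So does whether the amino nitrogen or the chlorohexyl chain drives the high number of compound 3, a question that a shorter alkylamino chain could address.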